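The source may hold more compounds than are shown below. What is called first, only, known or untested is meant among the compounds shown, and "the series" means these compounds.

Measured so far:
- compound 1, `Cn1cc(C(=O)Nc2ccc(-c3ccccn3)c(C(F)(F)F)c2)c(=O)c2ccccc21`: 5.2 ug/mL
- compound 2, `Cn1cc(C(=O)Nc2ccc(-c3ccccn3)c(C(F)(F)F)c2)c(=O)c2cnccc21`: 6.7 ug/mL
- compound 3, `Cn1nc(C(=O)Nc2ccc(-c3ccccc3)c(C(F)(F)F)c2)c(=O)c2ccccc21`: 12 ug/mL

In a physicochemical assay for solubility, in simulated intestinal fluid, at pH 7.4 (on this read-out higher numbers stand for higher solubility and lower numbers for lower solubility), compound 1 stands at the low end of the three numbers. The gap from compound 1 to compound 2 is within the scatter, so the two cannot be told apart on this read-out; the gap from compound 1 to compound 3 is beyond the scatter, compound 3 giving the higher number. Within the data shown here, compound 3 differs from compound 1 in more than one place, so no single step is defined between them.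

Compound 4, `Cn1cc(C(=O)Nc2ccc(-c3ccccc3)c(C(F)(F)F)c2)c(=O)c2ccccc21`, is not yet measured. Against compound 1 the change is phenyl in place of pyridin-2-yl on an aromatic carbon. Compound 3 also carries a phenyl at this position and gives 12 ug/mL in this assay, but its core is not that of compound 1, so its number cannot be read as the effect of this change alone.

For this assay a small step in compound 4 is expected, most likely downward or none beyond the scatter. Compound 4 is estimated at 3.5 ug/mL, range 1.2 ug/mL to 10 ug/mL, which means an expected step of a 1.5-fold lower number from compound 1 to compound 4 (0.17 log units; within the scatter).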

Compound 4, solubility: 11 ug/mL
Compound 4: middle estimate off by 3.1-fold (0.50 log units), on the low side; the whole stated range lies below it.
By their numbers in this assay, from the lowest: compounds 1, 2, 4 and 3 (each within the scatter of the next, the first and the last beyond it).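

In this assay, among these compounds, phenyl in place of pyridin-2-yl on the aromatic carbon ortho to a trifluoromethyl group gives a modest step, a 2.1-fold higher number from compound 1 to compound 4 (0.33 log units; beyond the scatter), the first single change at this position that can be read beyond the scatter on the core of compound 1. With phenyl at this position on both cores, compound 4 gives 11 ug/mL and compound 3 gives 12 ug/mL, which lie within the scatter of each other, so the two cores cannot be told apart in this pair. No measurement at hand accounts for the step at this position, and the comparison rests on this one pair.

Still open is whether phenyl in place of pyridin-2-yl gives a step of similar size on the core of compound 2, since that core is shown here only with pyridin-2-yl. On these data alone, it is also open how this assay responds at this position to other groups, such as pyridin-3-yl or a phenyl ring carrying an amine or a carboxylic acid.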